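A few compounds are considered here, and "the series" means these few. Any claim that something is new, unique, unknown or untested is made for them only; others in the source may bear on it.

Working notes on the phenylethynyl benzamide hydroxamates, solubility series.

Compound 3 `O=C(CNC(=O)c1ccc(C#Cc2ccccc2)cc1)NO` gives 21000 nM in a physicochemical assay for solubility (on this read-out lower numbers stand for lower solubility and higher numbers for higher solubility), the second highest of the three numbers measured. Its nearest neighbour is compound 2 `O=C(N[C@H](CO)C(=O)NO)c1ccc(C#Cc2ccccc2)cc1`, which gives 36000 nM; the two lie within the scatter, as the step of a 1.7-fold lower number from compound 2 to compound 3 (0.23 log units; within the scatter) shows. Furthest away is compound 1 `CSC[C@H](NC(=O)c1ccc(C#Cc2ccccc2)cc1)C(=O)NO`, which gives 2000 nM; the step of an 11-fold higher number from compound 1 to compound 3 (1.02 log units; beyond the scatter) is large and beyond the scatter.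

Compound 4 `O=C(NC1(C(=O)NO)CCC1)c1ccc(C#Cc2ccccc2)cc1` has not been measured. The change from compound 3 is 1-(hydroxycarbamoyl)cyclobutyl in place of (hydroxycarbamoyl)methyl on an amide-type nitrogen. The step that bears on it most directly is an 11-fold higher number from compound 1 to compound 3 (1.02 log units; beyond the scatter), where removing a carbon-bearing substituent from that chain carbon went with a much higher number; the step of a 1.7-fold lower number from compound 2 to compound 3 (0.23 log units; within the scatter) was within the scatter. Compound 4 puts a carbon-only ring on the same chain carbon, so a lower number in this assay is expected, smaller than the reverse of the step from compound 1, the expected step being a 3.5-fold lower number from compound 3 to compound 4 (0.54 log units; beyond the scatter). Compound 4 is estimated at 6000 nM, with a range from 2000 nM to 18000 nM.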

Compound 4, solubility: 5000 nM
Compound 4: the middle estimate sits 1.2-fold (0.08 log units) above what was measured; low and high end bracket the measured number.
By their numbers in this assay, from the lowest: compound 1; then compound 4; then compounds 3 and 2 (each within the scatter of the next).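

In this assay, the group on the amide-type nitrogen can now be seen to matter when it carries a ring of carbon only: with 1-(hydroxycarbamoyl)cyclobutyl in place of (hydroxycarbamoyl)methyl, the result is a 4.2-fold lower number from compound 3 to compound 4 (0.62 log units; beyond the scatter). The ring-bearing group also stands apart from the hydroxymethyl-bearing group, with a 7.2-fold lower number from compound 2 to compound 4 (0.86 log units; beyond the scatter), and from the (methylsulfanyl)methyl-bearing group, with a 2.5-fold higher number from compound 1 to compound 4 (0.40 log units; beyond the scatter), so compound 4 takes an intermediate place beyond the scatter of all three. No measurement on hand accounts for this order.

The compounds shown do not separate the effect of the ring from that of the added carbons, a question that two methyl groups on the same chain carbon would address. From the compounds shown here alone, how an amine or a carboxylic acid in this group would compare also remains open.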